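Two pyrazole series and one chloro-for-methyl swap

This account rests on a few compounds, and the source may have more. Where it says the series, first, only, none or still open, it means among the compounds named here.

Compound 1 `Cc1ccc(-c2cc(N)n(-c3cccc(Cl)c3)n2)cc1` was tested in a functional assay on Jurkat cells (Homo sapiens) for inhibition, read by MTT assay, with a stated time of 72 h (a lower number here means a stronger inhibitor of growth, a higher number a weaker inhibitor of growth), and gave 56600 nM. Compound 2 `Nc1cc(-c2ccc(Cl)cc2)nn1-c1cccc(Cl)c1` reached only a limit of this assay, > 100000 nM. The change between them, (chloro in place of methyl on an aromatic carbon), gave an at least 1.7-fold higher number from compound 1 to compound 2 (0.24 log units; that floor lies within the scatter); the floor of that step sits at the limit of > 100000 nM in this assay, at which 2 of the 3 values shown sit. Compound 3 `Cc1ccc(-c2cc(/N=C/N(C)C)n(-c3ccc(Br)cc3)n2)cc1` likewise gave only a limit in this assay, > 100000 nM. How the core of compound 3 differs from the core of compound 1 is not broken down here. Compound 4 `CN(C)/C=N/c1cc(-c2ccc(Cl)cc2)nn1-c1ccc(Br)cc1` carries the same kind of change relative to compound 3, (chloro in place of methyl on an aromatic carbon), and has not yet been measured. Since compound 3 already sits at the limit > 100000 nM, compound 4 is expected to stay at or beyond it, an estimated step that the limit leaves unreadable from compound 3 to compound 4. Compound 4 is therefore estimated at 150000 nM, between 60000 nM and 400000 nM.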

Compound 4, concentration for 50% growth inhibition: 84900 nM
Beside the measured number, compound 4's estimate is 1.8-fold (0.25 log units) above it; measured number inside the range.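

Carried to the core of compound 3, the change from 4-methylphenyl to 4-chlorophenyl gave, in this assay, an at least 1.1-fold lower number from compound 3 to compound 4 (0.07 log units; that floor lies within the scatter). Set beside the earlier step, the two readings stand as follows: the same change on two cores in this assay, an at least 1.7-fold higher number (0.24 log units; that floor lies within the scatter) from compound 1 to compound 2 and an at least 1.1-fold lower number (0.07 log units; that floor lies within the scatter) from compound 3 to compound 4; the limit leaves it open whether they differ. Each step has one end at a limit, so neither gives a true size for the change, and the data show neither that its effect carries from one core to the other nor that it fails to: the limit of > 100000 nM in this assay, at which 2 of the 4 values shown sit.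

Going by these compounds, it remains open how the change would read on a core where both partners give a number in this assay. On these data alone, it is equally open how a fluoro or a methoxy group would compare with chloro and methyl on that same aromatic carbon.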